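Swapping benzothiazole for benzoxazole: clearance of compound 3

A few compounds are considered here, and "the series" means these few. Any claim that something is new, unique, unknown or untested is made for them only; others in the source may bear on it.

Measured in an ADME assay (liver) for metabolic stability, with Liver microsome (Rattus norvegicus) as the target, using microsomes and NADPH, with a stated time of 30 min, tested at 1 uM; a higher number here means faster removal of the compound, a lower number slower removal:
- compound 1 `Nc1ccc(S(=O)(=O)N2CCN(c3ncc(C(O)(C(F)(F)F)C(F)(F)F)cc3C3CC3)CC2)cn1`: 27 mL.min-1.g-1
- compound 2 `Nc1ccc(S(=O)(=O)N2CCN(c3ncc(C(O)(C(F)(F)F)C(F)(F)F)cc3-c3ccc4scnc4c3)CC2)cn1`: 147 mL.min-1.g-1

Of these two numbers, compound 2 stands highest at 147 mL.min-1.g-1, well clear of compound 1 at 27 mL.min-1.g-1. Within the data shown here, the next structure, compound 3 `Nc1ccc(S(=O)(=O)N2CCN(c3ncc(C(O)(C(F)(F)F)C(F)(F)F)cc3-c3ccc4ocnc4c3)CC2)cn1`, changes only one group, on an aromatic carbon of a six-membered aromatic ring with 1 nitrogen: 1,3-benzoxazol-5-yl in place of 1,3-benzothiazol-5-yl on an aromatic carbon. Among the measured compounds shown here, only one measured step bears on this, and only indirectly: a 5.4-fold higher number from compound 1 to compound 2 (0.74 log units; beyond the scatter), beyond the scatter, where 1,3-benzothiazol-5-yl took the place of cyclopropyl. That was a change of a much larger kind. For the measured compounds named here, the present swap exchanges sulfur for oxygen and leaves the other counted features alike, and no measured pair tests it directly. A small move downward at most is therefore expected, with nothing beyond the scatter in this assay. The expected change is a 1.2-fold lower number from compound 2 to compound 3 (0.09 log units; within the scatter). For compound 3 the estimated value is 120 mL.min-1.g-1, with an expected range of 60 mL.min-1.g-1 to 220 mL.min-1.g-1.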

Compound 3, intrinsic clearance in microsomes: 120 mL.min-1.g-1
Beside the measured number, compound 3's estimate shows no gap at the digits printed; the measured number falls inside the stated range.
By their numbers in this assay, from the lowest: compound 1; then compounds 3 and 2 (each within the scatter of the next).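

In this assay, the exchange of sulfur for oxygen in the fused group gives a 1.2-fold lower number from compound 2 to compound 3 (0.09 log units; within the scatter), so at this position 1,3-benzoxazol-5-yl and 1,3-benzothiazol-5-yl cannot be told apart in this read-out. The step from cyclopropyl now has a second example, as 1,3-benzoxazol-5-yl in place of cyclopropyl gives a 4.4-fold higher number from compound 1 to compound 3 (0.65 log units; beyond the scatter) and both fused groups stand clear of the scatter around compound 1. No measurement shown here accounts for these numbers or says which part of any compound is affected.

From the compounds shown here alone, whether a plain phenyl ring or a morpholine at this place would behave like cyclopropyl or like the two fused groups remains open. Also open, going by these compounds, is whether the same picture would hold with an amine in place of the 2,2,2-trifluoro-1-hydroxy-1-(trifluoromethyl)ethyl group.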